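Compound 3 to compound 4: a flat series so far

The source may report more compounds than this note shows. Statements on the series, on what has been measured and on what is new or still open speak of the compounds shown alone.

In a toxicity assay on CHO cells (Cricetulus griseus) for cytotoxicity, read by MTT assay (on this read-out lower numbers stand for stronger inhibition and higher numbers for weaker inhibition), compound 3 (`COc1ccc(/C=N/NC(=O)c2cn(C3CC3)c3cc(N4CCNCC4)c(F)cc3c2=O)cc1O`) gives 25000 nM. It stands level with the other two measured compounds: compound 1 (`O=C(N/N=C/c1ccc(F)cc1)c1cn(C2CC2)c2cc(N3CCNCC3)c(F)cc2c1=O`) gives 25000 nM and compound 2 (`O=C(N/N=C/c1ccccc1)c1cn(C2CC2)c2cc(N3CCNCC3)c(F)cc2c1=O`) gives 25000 nM.

Compound 4 (`O=C(N/N=C/c1ccc([N+](=O)[O-])cc1)c1cn(C2CC2)c2cc(N3CCNCC3)c(F)cc2c1=O`) has not yet been measured. The structural change is 4-nitrophenyl in place of 3-hydroxy-4-methoxyphenyl on a carbon with a double bond to nitrogen.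

Two measured steps act at this same place. Putting 3-hydroxy-4-methoxyphenyl in place of 4-fluorophenyl gave no change at the digits printed from compound 1 to compound 3 (within the scatter), and putting it in place of phenyl gave no change at the digits printed from compound 2 to compound 3 (within the scatter). A third step, hydrogen in place of fluoro on an aromatic carbon, gave no change at the digits printed from compound 1 to compound 2 (within the scatter). All three steps are flat, so none offers a direction to carry forward. Among the compounds with values here, none of the measured compounds carries 4-nitrophenyl, however, and three compounds make a thin basis for any expectation.

The expected step in this assay is no change at the digits printed from compound 3 to compound 4 (within the scatter), with nothing expected beyond the scatter in either direction. For compound 4 the estimate is 25000 nM, with an expected range of 12000 nM to 50000 nM.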

Compound 4, half-maximal inhibitory concentration: 25000 nM
Estimate against measurement, compound 4: no gap at the digits printed; measured number inside the range.
By their numbers in this assay, from the lowest: compounds 1, 2, 3 and 4 (each within the scatter of the next).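

Working notes on the series: in this assay the step to 4-nitrophenyl in place of 3-hydroxy-4-methoxyphenyl, on a carbon with a double bond to nitrogen, gives no change at the digits printed from compound 3 to compound 4 (within the scatter) and extends the flat read to a group with 0 hydrogen-bond donors and 1 double bond outside aromatic rings. Nitro in place of hydrogen on an aromatic carbon gives no change at the digits printed from compound 2 to compound 4 (within the scatter) and nitro in place of fluoro on an aromatic carbon gives no change at the digits printed from compound 1 to compound 4 (within the scatter) so that, among these four compounds, no aryl group at this position separates from another in this assay and no compound goes against this flat pattern. Nothing on hand bears on why the read-out stays level at this position.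

Still open, going by these compounds, is whether a carboxylic acid or a dimethylamino group on the phenyl, or a longer alkyl chain in place of the phenyl, would move the value beyond the scatter. On these data alone, the shared core is the same in all four compounds, so the effect of any change elsewhere on it remains unknown in this assay.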